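The source may hold more compounds than are shown below. What is called first, only, known or untested is meant among the compounds shown, and "the series" means these compounds.

Compound 1 `CNC(=O)c1cc(Oc2ccc(C(=O)/C=C/c3ccc(Br)cc3)cc2)ccn1`: 18500 nM
Compound 2 `CNC(=O)c1cc(Oc2ccc(C(=O)/C=C/c3cccc([N+](=O)[O-])c3)cc2)ccn1`: "not determined" (no result reported)

Within the data shown here, in a functional assay on PC-3 cells (Homo sapiens) for cytotoxicity, read by MTT assay, with a stated time of 72 h (a higher number here means a weaker inhibitor, a lower number a stronger inhibitor), compound 1 gives 18500 nM, the only number so far. For compound 2 the entry reads "not determined" (no result reported), so compound 2 has no place on this scale and cannot be called stronger or weaker than compound 1.

Compound 3 `CNC(=O)c1cc(Oc2ccc(C(=O)/C=C/c3cccc(Cl)c3Cl)cc2)ccn1` is built from compound 2 by one change: 2,3-dichlorophenyl in place of 3-nitrophenyl on a double-bonded chain carbon bound to a double-bonded chain carbon. In words, 2,3-dichlorophenyl stands in place of 3-nitrophenyl on a double-bonded chain carbon bound to a double-bonded chain carbon.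

Among the measured compounds shown here, no measured pair shows what a change at this place does in this assay. For the measured compounds named here, with no such step to go on, no shift in either direction beyond the usual scatter is expected, and the only anchor is compound 1 at 18500 nM. Compound 3 is expected at about 15000 nM, within an estimated range of 5000 nM to 40000 nM.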

Compound 3, half-maximal inhibitory concentration: > 50000 nM
Compound 3: a limit, no number; the forecaster's own chance of this, stated with the estimate: 15%; at least 3.3-fold (0.52 log units) between middle value and limit.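

In this assay compound 3 gives > 50000 nM, which is a limit of the assay and not a number. Changing the substituted phenyl group gives an at least 2.7-fold higher number from compound 1 to compound 3 (0.43 log units; beyond the scatter), the first sign that this position is not indifferent to which substituted phenyl it carries, with the dichloro group giving the weaker result. The true size of this step stays unknown, and it rests on a reading that has no exact value: the limit of > 50000 nM in this assay, at which 1 of the 3 values shown sits.

The step from compound 2 to compound 3 cannot be read, as compound 2 has no number. Also open, on these data alone, are whether the count of halogens or their place on the ring matters here, and what a phenyl carrying an amine or a carboxylic acid would give at this position.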